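The source may report more compounds than this note shows. Statements on the series, on what has been measured and on what is new or still open speak of the compounds shown alone.

In a functional assay on HeLa cells (Homo sapiens) for inhibition, read by MTT assay, with a stated time of 72 h (a lower number here means a stronger inhibitor, a higher number a weaker inhibitor), three compounds of a shared core have been measured, and all of them sit at the weak end of the scale. Compound 1 `O=c1cc(Cn2cc(CCO)nn2)c2ccc(O)cc2o1` gives only a limit of this assay, > 100000 nM. For the measured compounds named here, compound 2 `O=c1cc(Cn2cc(CCCO)nn2)c2ccc(O)cc2o1` gives 90200 nM, the single number among the three. Compound 3 `O=c1cc(Cn2cc(CCCCO)nn2)c2ccc(O)cc2o1` again gives only a limit, > 100000 nM.

The steps between them are small: an at least 1.1-fold lower number from compound 1 to compound 2 (0.04 log units; that floor lies within the scatter), and an at least 1.1-fold higher number from compound 2 to compound 3 (0.04 log units; that floor lies within the scatter), while a step that the two limits leave unreadable from compound 1 to compound 3. That the steps read so flat follows from the limit of > 100000 nM in this assay, at which 2 of the 3 values shown sit, which caps two of the three values.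

Compound 4 `CC(C)(C)c1cn(Cc2cc(=O)oc3cc(O)ccc23)nn1` differs from compound 3 in one place: tert-butyl in place of 4-hydroxybutyl on an aromatic carbon. Going by the values given here, none of the measured steps bears on such a change; all three move a hydroxy group by one chain carbon, whereas here the hydroxyl leaves with its donor and acceptor and a tert-butyl enters. Among the compounds with values here, there is no measured step whose size could be carried over.

Compound 3 stands at the limit of this assay, and compound 4 is therefore expected to stay close to it, estimated at 100000 nM, in a range from 35000 nM to 300000 nM. The change this implies, a number no higher from compound 3 to compound 4 (the limit leaves the size open), is expected to lie within the scatter.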

Compound 4, half-maximal inhibitory concentration: 81100 nM
The estimate for compound 4 lay 1.2-fold (0.09 log units) above the measured number; low and high end bracket the measured number.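

For the compounds shown here, the result shows that, on this aromatic carbon of the five-membered ring, tert-butyl, with 0 hydrogen-bond donors and 0 hydrogen-bond acceptors, can stand where a hydroxy-bearing chain stood without the compound leaving the weak end of this assay: the one comparison between two exact numbers is a 1.1-fold lower number from compound 2 to compound 4 (0.05 log units; within the scatter). Against the two compounds held at a limit, the steps are an at least 1.2-fold lower number from compound 3 to compound 4 (0.09 log units; that floor lies within the scatter) and an at least 1.2-fold lower number from compound 1 to compound 4 (0.09 log units; that floor lies within the scatter), and each of these gives only a floor. The earlier compounds shown here varied only the length of the hydroxy-bearing chain, whereas compound 4 gives 81100 nM with no hydroxy group on this substituent at all, so a hydroxy group here is not required for a readable number in this assay.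

As far as these compounds go, whether an amine, a carboxylic acid or a longer chain at this position would move the number out of this weak range stays open. The true size of the steps from compound 1 and compound 3 also stays open: the limit of > 100000 nM in this assay, at which 2 of the 4 values shown sit.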